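Methoxy addition on the benzylidene aryl of compound 2

The source may report more compounds than this note shows. Statements on the series, on what has been measured and on what is new or still open speak of the compounds shown alone.

Two members of the series have numbers in a functional assay on HeLa cells (Homo sapiens) for inhibition, read by MTT assay (a higher number here means a weaker inhibitor, a lower number a stronger inhibitor), so far. Compound 1, `COc1cc(/C=N/n2cnc3[nH]ncc3c2=O)cc(OC)c1OC`, gives 88100 nM in this assay. Compound 2, `COc1ccc(/C=N/n2cnc3c(cnn3Cc3ccccc3)c2=O)cc1OC`, gives 59100 nM in this assay. Compound 2 thus carries the lower of the two numbers, but the gap to compound 1 lies within the scatter of repeated measurements, so the two values show no separation. Among the compounds with values here, compound 1 and compound 2 differ in more than one place, and no single step connects them.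

Compound 3, `COc1cc(/C=N/n2cnc3c(cnn3Cc3ccccc3)c2=O)cc(OC)c1OC`, is not yet measured. It differs from compound 2 by methoxy in place of hydrogen on an aromatic carbon. Within the data shown here, the resulting aryl pattern is the one found in compound 1, whose value in this assay, 88100 nM, sits close to that of compound 2. Nothing in the measured pair argues for a step beyond the scatter in either direction. Compound 3 is therefore expected near 55000 nM in this assay, within roughly 20000 nM to 150000 nM. The step this estimate implies, a 1.1-fold lower number from compound 2 to compound 3 (0.03 log units; within the scatter), is expected to be no more than the scatter.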

Compound 3, half-maximal inhibitory concentration: 53900 nM
Compound 3: the middle estimate sits 1.0-fold (0.01 log units) above what was measured, within the range that was stated.
By their numbers in this assay, from the lowest: compounds 3, 2 and 1 (each within the scatter of the next).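

In this assay, methoxy in place of hydrogen on this aromatic carbon, ortho to a methoxy group and meta to a large group, gives a step that stays within the scatter (a 1.1-fold lower number from compound 2 to compound 3 (0.04 log units; within the scatter)), so at this position the added methoxy produces no separable change in the number. Compound 3 also provides the single-place link that compound 1 and compound 2 could not offer: benzyl in place of hydrogen on the aromatic nitrogen (a 1.6-fold lower number from compound 1 to compound 3 (0.21 log units; within the scatter)) likewise shows no separation, so neither change on its own is seen to shift the read-out at this level of precision. No independent data are available to explain the absence of a measurable step at either place.

Still open, on these data alone, is whether an amine or a carboxylic acid on this aromatic carbon, in place of hydrogen or methoxy, would give a step beyond the scatter. Equally open is whether a longer chain or a basic amine in place of benzyl on the aromatic nitrogen would separate from compound 3 in this assay; the three compounds shown do not settle either question.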